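The source may report more compounds than this note shows. Statements on the series, on what has been measured and on what is new or still open speak of the compounds shown alone.

Three compounds have been measured so far:
Compound 1, `O=S(=O)(NCCNCc1ccc(-c2ccccc2)cc1)c1cc(C(F)(F)F)cc(C(F)(F)F)c1`, gives 1600 nM in a functional assay on BXPC-3 cells (Homo sapiens) for inhibition, read by MTT assay, with a stated time of 72 h; on this read-out higher numbers stand for weaker inhibition of growth and lower numbers for stronger inhibition of growth.
Compound 2, `COc1ccc(CNCCCNS(=O)(=O)c2cc(C(F)(F)F)cc(C(F)(F)F)c2)cc1OC`, gives 13000 nM in this assay.
Compound 3, `O=S(=O)(NCCCNCc1ccc(-c2ccccc2)cc1)c1cc(C(F)(F)F)cc(C(F)(F)F)c1`, gives 1700 nM in this assay.

All three share the same core, differing only in the length of the chain and in the group at its far end. Within this small set compound 2 stands at the top: its number is the highest of the three, beyond the usual scatter from both compound 3 and compound 1, so on this read-out it inhibits growth the least. Compound 1 and compound 3 lie within the scatter of each other.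

The next compound, compound 4, `O=S(=O)(NCCCNCc1cccc(Cl)c1)c1cc(C(F)(F)F)cc(C(F)(F)F)c1`, keeps the chain of compound 2 and alters one group: 3-chlorophenyl in place of 3,4-dimethoxyphenyl on a saturated chain carbon bound to an amine nitrogen. Within the data shown here, no measured pair differs in exactly this way, so there is no measured step to lean on. The two compounds that carry a biphenyl group sit far below compound 2, which shows that a group other than 3,4-dimethoxyphenyl can go with a much lower number. A moderate move toward stronger inhibition in this assay is therefore expected, likely beyond the scatter, though this remains uncertain. Compound 4 is estimated at 5000 nM, within 1500 nM to 16000 nM, an expected step of a 2.6-fold lower number from compound 2 to compound 4 (0.41 log units; beyond the scatter).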

Compound 4, concentration for 50% growth inhibition: 3800 nM
Beside the measured number, compound 4's estimate is 1.3-fold (0.12 log units) above it, and the stated range covers the measured number.
By their numbers in this assay, from the lowest: compounds 1 and 3 (each within the scatter of the next); then compound 4; then compound 2.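

In this assay, moving from 3,4-dimethoxybenzyl to 3-chlorobenzyl on the same chain gives a 3.4-fold lower number from compound 2 to compound 4 (0.53 log units; beyond the scatter), so this position responds to a change between two singly substituted or doubly substituted benzyl groups even when the new group is smaller, with fewer heavy atoms and no hydrogen-bond acceptors. A lower number here therefore does not depend on the large biphenyl group, although compound 4 gives 3800 nM and compound 3 gives 1700 nM, which leaves compound 4 the higher of the two. Nothing available explains why this swap lowers the number.

The swap removes two methoxy groups and adds a chlorine in a single step, so the compounds shown cannot separate the two, and a plain phenyl group or a group carrying a single methoxy would be needed to tell them apart. On these data alone, it also remains open whether the 3-chlorobenzyl group would give a similar step on the shorter chain of compound 1, or whether a fluorine or a bromine in place of the chlorine would move the number further.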